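Hydroxyphenyl and thienyl analogs: cytotoxicity working notes

The source may report more compounds than this note shows. Statements on the series, on what has been measured and on what is new or still open speak of the compounds shown alone.

Measured so far:
compound 1 `Oc1ccc(-c2cc(-c3cccs3)cc(-c3ccccc3O)n2)cc1` — > 50000 nM
compound 2 `Oc1cccc(-c2cc(-c3ccsc3)cc(-c3ccccc3O)n2)c1` — > 50000 nM

In a functional assay on HeLa cells (Homo sapiens) for cytotoxicity, read by CCK-8 assay (a higher number here means a weaker inhibitor, a lower number a stronger inhibitor), compound 1 gives > 50000 nM, which is the assay limit and not a number. Compound 2 likewise gives > 50000 nM, again a limit rather than a number. Compound 2 therefore stands at the limit of > 50000 nM in this assay, at which 2 of the 2 values shown sit, and no numerical value is known for either compound. Among the measured compounds shown here, compound 3 `Oc1ccc(-c2cc(-c3ccsc3)cc(-c3ccccc3O)n2)cc1` differs from compound 2 by 4-hydroxyphenyl in place of 3-hydroxyphenyl on an aromatic carbon; no measured pair shows this change. Compound 3 is expected to remain at the limit, so the expected step that the limit leaves unreadable from compound 2 to compound 3 is none beyond the scatter. For compound 3 the estimate is 80000 nM, with a range from 20000 nM to 300000 nM, most likely reported only as a limit.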

Compound 3, half-maximal inhibitory concentration: > 50000 nM
Compound 3: only a limit was reported; the forecaster's own chance of this, stated with the estimate: 85%; the middle value is on the limit's open side.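

No step can be read between compound 3 and compound 1 or compound 2, as all three stand at a limit and not a number: the limit of > 50000 nM in this assay, at which 3 of the 3 values shown sit.

Still open, going by these compounds, is whether 4-hydroxyphenyl versus 3-hydroxyphenyl, or thiophen-3-yl versus thiophen-2-yl, changes the read-out in this assay at all.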